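A few compounds are considered here, and "the series" means these few. Any claim that something is new, unique, unknown or untested is made for them only; others in the source may bear on it.

Measured so far in a functional assay on MCF7 cells (Homo sapiens) for cytotoxicity, read by sulforhodamine B assay, with a stated time of 48 h; on this read-out lower numbers stand for stronger inhibition of growth and higher numbers for weaker inhibition of growth:
compound 1, `NC(=S)N/N=C1/C(=O)N(CN2CCN(c3ccnc4cc(C(F)(F)F)ccc34)CC2)c2cc(Cl)ccc21`, 24600 nM
compound 2, `NC(=S)N/N=C1/C(=O)N(CN2CCN(c3ccnc4cc(C(F)(F)F)ccc34)CC2)c2cc(Br)ccc21`, 35500 nM
compound 3, `NC(=S)N/N=C1\C(=O)Nc2cccc(Cl)c21`, 30200 nM

Compound 1 and compound 2 differ by bromo in place of chloro on an aromatic carbon; that step in this assay is a 1.4-fold higher number from compound 1 to compound 2 (0.16 log units; within the scatter). Compound 4, `NC(=S)N/N=C1\C(=O)Nc2cccc(Br)c21`, is not yet measured; it differs from compound 3 by bromo in place of chloro on an aromatic carbon. This is the same kind of change as from compound 1 to compound 2, though around the place it differs: in compound 1 to compound 2 the carbon is meta to a fused ring and para to a fused ring, in compound 3 to compound 4 it is ortho to a fused ring and meta to a fused ring. The difference between the core of compound 1 and the core of compound 3 is not broken down here. Compound 3 and compound 2 give values within the scatter of each other, and the same holds for compound 3 and compound 1.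

The expected step in this assay from compound 3 to compound 4 is a 1.3-fold higher number from compound 3 to compound 4 (0.10 log units; within the scatter), resting on compound 1 to compound 2 giving a 1.4-fold higher number from compound 1 to compound 2 (0.16 log units; within the scatter). Compound 4 in this assay is therefore estimated at 38000 nM, expected between 20000 nM and 75000 nM.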

Compound 4, concentration for 50% growth inhibition: 14800 nM
The estimate for compound 4 lay 2.6-fold (0.41 log units) above the measured number; the measured number lies below the stated range.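

In this assay bromo in place of chloro on an aromatic carbon gives a 2.0-fold lower number from compound 3 to compound 4 (0.31 log units; beyond the scatter) and is a modest step on this core. The change does not carry over from one core to the other with the same size or direction: the same change on two cores in this assay, a 1.4-fold higher number (0.16 log units; within the scatter) from compound 1 to compound 2 and a 2.0-fold lower number (0.31 log units; beyond the scatter) from compound 3 to compound 4, 2.9-fold (0.47 log units) apart, beyond the scatter of two such steps

Only one pair per core is at hand, and the two pairs differ both in the core and in the place of the halogen on the aromatic ring, so what separates the two steps is not shown. Still open, going by these compounds, is how fluoro, methyl or methoxy at the same place on the core of compound 3 would compare with chloro and bromo. Also open, on these data alone, is whether an amine there would follow the same course on the core of compound 1.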